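Removing a Ring Chloro, Adding a Methyl on the Alkene

The compounds below may be only part of what the source reports. "The series", "measured", "known", "first", "only" and "open" are said of these compounds alone.

In a functional assay on thoracic aorta for inhibition of Voltage-gated L-type calcium channel (Rattus norvegicus) (a lower number here means a stronger inhibitor, a higher number a weaker inhibitor), compound 3 `CC1=NC(C)=C(C(=O)O)C(c2cccc(Cl)c2)/C1=C(\O)OC/C=C/c1ccc(Cl)cc1` gives 5.8 nM, the lowest of the three numbers shown. Compound 2 `CC1=NC(C)=C(C(=O)O)C(c2cccc(Br)c2)/C1=C(\O)OC/C=C/c1ccccc1` gives 10 nM, which sits within the scatter of compound 3, while compound 1 `CC1=NC(C)=C(C(=O)O)C(c2cccc(Cl)c2)/C1=C(\O)OC/C=C/c1ccccc1` gives 20 nM, beyond it. Compound 4 `CC1=NC(C)=C(C(=O)O)C(c2cccc(Cl)c2)/C1=C(\O)OC/C(C)=C/c1ccccc1` differs from compound 3 by 1-methyl-2-phenylethenyl in place of 2-(4-chlorophenyl)ethenyl on a saturated chain carbon bound to an oxygen on an unsaturated carbon. Among the compounds with values here, one measured step bears on this: a 3.4-fold lower number from compound 1 to compound 3 (0.54 log units; beyond the scatter), which compound 4 undoes. Within the data shown here, the methyl that enters on the alkene has no precedent among the measured compounds, and a 2.0-fold lower number from compound 1 to compound 2 (0.30 log units; within the scatter) concerns the other ring. The expected step is therefore a 3.4-fold higher number from compound 3 to compound 4 (0.54 log units; beyond the scatter), roughly a return to the level of compound 1. Compound 4 is estimated at 20 nM, in the range 7 nM to 60 nM.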

Compound 4, half-maximal inhibitory concentration: 2.8 nM
Beside the measured number, compound 4's estimate is 7.1-fold (0.85 log units) above it; the whole stated range lies above it.
By their numbers in this assay, from the lowest: compound 4; then compounds 3, 2 and 1 (each within the scatter of the next, the first and the last beyond it).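

In this assay, a methyl on the alkene moves the number at least as far as the ring chloro it replaces: the change gives a 2.1-fold lower number from compound 3 to compound 4 (0.32 log units; beyond the scatter). Seen alone, with no chloro on either side, the methyl gives a 7.1-fold lower number from compound 1 to compound 4 (0.85 log units; beyond the scatter), so the alkene of this chain, and not just its far phenyl ring, is a place where a change shifts the number. Nothing measured here gives a reason for either step.

Open, as far as these compounds go, is whether the methyl and the ring chloro together would lower the number further. Also open, from the compounds shown here alone, is how an ethyl in place of that methyl, or an amine on the phenyl ring, would behave.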